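Amide substituent and half-life in rat microsomes

A few compounds are considered here, and "the series" means these few. Any claim that something is new, unique, unknown or untested is made for them only; others in the source may bear on it.

Measured compounds:
compound 1, `Cc1c2c(n3c1CCN(C(=O)CN)C[C@@H](C)[C@H](C)Nc1cc-3ccc1C(N)=O)CC(C)(C)CC2=O`: > 0.5 h
compound 2, `Cc1c2c(n3c1CCN(C(=O)[C@@H](N)C(C)C)C[C@@H](C)[C@H](C)Nc1cc-3ccc1C(N)=O)CC(C)(C)CC2=O`: 0.217 h

In an in vitro ADME assay on microsomes (Rattus norvegicus) for metabolic stability (a lower number here means that the compound disappears faster, a higher number that the compound lasts longer), compound 1 gives > 0.5 h, which is a limit of the assay and not a number. Among the measured compounds shown here, compound 2 gives 0.217 h, the only number in the set so far. For the measured compounds named here, the one further value belongs to compound 1 and is a limit (the limit of > 0.5 h in this assay, at which 1 of the 2 values shown sits). Going by the values given here, the single measured step is an at least 2.3-fold lower number from compound 1 to compound 2 (0.36 log units; beyond the scatter), at least modest and beyond the scatter.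

Compound 3, `Cc1c2c(n3c1CCN(C(=O)C1(N)CC1)C[C@@H](C)[C@H](C)Nc1cc-3ccc1C(N)=O)CC(C)(C)CC2=O`, differs from compound 2 by 1-aminocyclopropyl in place of 1-amino-2-methylpropyl on a carbonyl carbon. The step from compound 1 to compound 2 bears on it: isopropyl entering the same carbon cost half-life there, and compound 3 removes the isopropyl without returning to hydrogen. A modest rise is therefore expected, a 1.6-fold higher number from compound 2 to compound 3 (0.21 log units; within the scatter), leaving compound 3 short of where compound 1 sits. For compound 3 the estimate is 0.35 h, with a range from 0.2 h to 0.6 h.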

Compound 3, half-life: > 0.5 h
Compound 3: no number, only a limit (the forecaster's own chance of this, stated with the estimate: 25%); middle value at least 1.4-fold (0.15 log units) away from the limit.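

In this assay compound 3 gives > 0.5 h, which is a limit of the assay and not a number. The change to 1-aminocyclopropyl on a carbonyl carbon gives an at least 2.3-fold higher number from compound 2 to compound 3 (0.36 log units; beyond the scatter), so the shorter half-life of compound 2 does not extend to every replacement of hydrogen on the carbon bearing the amine; this is a finding for these compounds only. The step from compound 1 to compound 3 cannot be read: the limit of > 0.5 h in this assay, at which 2 of the 3 values shown sit.

Going by these compounds, how compound 1 and compound 3 rank against each other stays open. Also open, on these data alone, is whether a group with a larger ring, such as 1-aminocyclobutyl, or an open-chain group such as 1-aminoethyl, on the same carbonyl carbon would reach that limit in this assay or fall short of it.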